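The compounds below may be only part of what the source reports. "The series", "measured", "known", "first", "only" and "open" are said of these compounds alone.

Within the data shown here, compound 2 `CCN(CC)C(=O)c1cccn1-c1ccc(Nc2ncc(Cl)c(Nc3ccccc3NS(C)(=O)=O)n2)c(OC)c1` is the stronger of the two compounds measured so far. Among the measured compounds shown here, in a functional assay on KARPAS-299 cells (Homo sapiens) for antiproliferative activity, read by MTT assay, with a stated time of 4 h (on this read-out higher numbers stand for weaker inhibition and lower numbers for stronger inhibition), compound 2 gives 105 nM, while its single neighbour, compound 1 `COc1cc(-n2cccc2C(=O)N2CCCC2)ccc1Nc1ncc(Cl)c(Nc2ccccc2NS(C)(=O)=O)n1`, gives 870 nM in this assay. For the measured compounds named here, the only step recorded between them, an 8.3-fold lower number from compound 1 to compound 2 (0.92 log units; beyond the scatter), shows that the amine attached to the carbonyl carbon is a place where this assay responds.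

Compound 3 `COc1cc(-n2cccc2C(=O)N2CC(O)C2)ccc1Nc1ncc(Cl)c(Nc2ccccc2NS(C)(=O)=O)n1` differs from compound 2 in exactly that place: 3-hydroxyazetidin-1-yl in place of diethylamino on a carbonyl carbon. Going by the values given here, no measured pair shows this exact exchange; the only step that bears on it is the one from compound 1 to compound 2, where an open diethylamino group gave the lower number and a ring-shaped amine the higher one. Since the new group is again a ring, and the earlier ring gave a weaker number than the diethylamino of compound 2, a modest move back towards the weaker side is expected, a 3.8-fold higher number from compound 2 to compound 3 (0.58 log units; beyond the scatter). The estimate for compound 3 in this assay is therefore 400 nM, with a range from 100 nM to 1600 nM.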

Compound 3, half-maximal inhibitory concentration: 81 nM
Beside the measured number, compound 3's estimate is 4.9-fold (0.69 log units) above it; the whole stated range lies above it.
By their numbers in this assay, from the lowest: compounds 3 and 2 (each within the scatter of the next); then compound 1.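

In this assay the step of a 1.3-fold lower number from compound 2 to compound 3 (0.11 log units; within the scatter) places the 3-hydroxyazetidin-1-yl amide level with the diethylamino amide, so an open chain on this carbonyl carbon is not required for the stronger numbers. The step of an 11-fold lower number from compound 1 to compound 3 (1.03 log units; beyond the scatter) shows that ring-shaped amines at this place can differ widely, and the earlier gap between compound 1 and compound 2 therefore cannot be read as a simple contrast of ring against open chain; of the three compounds, compound 1 alone stands apart. The two groups in compound 2 and compound 3 have the same heavy-atom count but differ in ring, donor and acceptor counts, yet their numbers cannot be told apart here, and no supporting data explain this result.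

The compounds shown leave open whether the hydroxyl or the four-membered ring accounts for the separation of compound 3 from compound 1, a question that plain azetidin-1-yl would help to settle. They also leave open how this place would respond to larger amines such as piperidin-1-yl or morpholin-4-yl.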